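From methyl to ethyl on the shared core

A few compounds are considered here, and "the series" means these few. Any claim that something is new, unique, unknown or untested is made for them only; others in the source may bear on it.

Values so far in a functional assay on the whole organism (brain) with Mus musculus as the target; a higher number here means that more compound is needed for the effect, a lower number that less compound is needed
- compound 1 `COC(=O)c1ccc(OCCc2c[nH]cn2)cc1` gives > 3 mg/kg as a limit of the assay
- compound 2 `Cc1ccc(OCCc2c[nH]cn2)cc1` gives 2.3 mg/kg as a number

Going by the values given here, compound 2 holds the only actual number so far. Compound 3 `CCc1ccc(OCCc2c[nH]cn2)cc1` differs from it by methyl in place of hydrogen on a saturated chain carbon bound to an aromatic carbon and carries methyl in place of hydrogen on a saturated chain carbon bound to an aromatic carbon. Among the compounds with values here, the only measured step is an at least 1.3-fold lower number from compound 1 to compound 2 (0.11 log units; that floor lies within the scatter) and it concerns an aromatic carbon rather than the chain carbon, so it offers little guide to size. The expected step in this assay is a 1.2-fold lower number from compound 2 to compound 3 (0.06 log units; within the scatter) and no shift beyond the scatter is anticipated. Compound 3 is estimated at 2 mg/kg with an expected range from 0.8 mg/kg to 3 mg/kg in this measure.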

Compound 3, dose for half-maximal effect: > 10 mg/kg
Compound 3 was reported as a limit; the forecaster's own chance of this, stated with the estimate: 20%; at least 5.0-fold (0.69 log units) between middle value and limit.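

In this assay, the methyl to ethyl change gives an at least 4.3-fold higher number from compound 2 to compound 3 (0.63 log units; beyond the scatter). Unlike the earlier step on the aromatic carbon, whose floor lay within the scatter, this step shows that one added methyl on the saturated chain carbon bound to an aromatic carbon is enough to move the number beyond the scatter. Compound 3 is reported only as a limit of the assay: the limit of > 10 mg/kg in this assay, at which 1 of the 3 values shown sits.

The step from compound 1 to compound 3 cannot be read. On these data alone, whether a longer chain such as propyl or a hydroxyl on that chain carbon would stay near compound 2 remains open.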